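A few compounds are considered here, and "the series" means these few. Any claim that something is new, unique, unknown or untested is made for them only; others in the source may bear on it.

Measured compounds:
Compound 1, `Nc1cc(N)c2nc(-c3ccccc3)c(NCc3ccc(F)cc3)nc2c1`, gives 9770 nM in a functional assay on DU-145 cells (Homo sapiens) for inhibition, read by sulforhodamine B assay, with a stated time of 48 h; on this read-out lower numbers stand for higher toxicity in this test and higher numbers for lower toxicity in this test.
Compound 2, `COc1ccc(Sc2nc3cc(N)cc(N)c3nc2-c2ccccc2)cc1`, gives 69200 nM in this assay.

Of the two numbers in this assay, compound 2 holds the higher one; its nearest neighbour is compound 1, and the step of a 7.1-fold higher number from compound 1 to compound 2 (0.85 log units; beyond the scatter) separates them. That step exchanges (4-fluorobenzyl)amino for (4-methoxyphenyl)sulfanyl on an aromatic carbon of the shared core.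

Compound 3, `Nc1cc(N)c2nc(-c3ccccc3)c(Sc3ccc(F)cc3)nc2c1`, keeps the sulfanyl link of compound 2 and differs only in fluoro in place of methoxy on an aromatic carbon, on an aromatic carbon of a six-membered aromatic ring of carbon only, para to a large group. Among the measured compounds shown here, no measured step exchanges these two groups on an otherwise unchanged compound; the step from compound 1 to compound 2 changes both the link and the ring substituent at once, so it cannot be separated into parts. Compound 3 is therefore expected to stay near compound 2, with at most a modest move, and the step of a 1.4-fold lower number from compound 2 to compound 3 (0.14 log units; within the scatter) is the expected size. The estimate for compound 3 in this assay is 50000 nM, within 15000 nM to 150000 nM.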

Compound 3, concentration lethal to 50% of the cells: < 100000 nM
Compound 3 ended at the assay's limit; the forecaster's own chance of this, stated with the estimate: 10%; the middle value lies beyond the limit too.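

Compound 3 gives < 100000 nM in this assay, which is a limit of the assay and not a number. The steps to compound 3 from compound 1 and from compound 2 therefore cannot be read: the limit of < 100000 nM in this assay, at which 1 of the 3 values shown sits.

The compounds shown leave open how far fluoro in place of methoxy moves the number in this assay.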